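Chloro in Place of Bromo: An Expectation for Compound 4

The compounds below may be only part of what the source reports. "The series", "measured", "known", "first", "only" and "open" are said of these compounds alone.

Three compounds have been measured in a functional assay on cells (Melanoma cell, Homo sapiens) for cytotoxicity, read by sulforhodamine B assay, with a stated time of 48 h; a lower number here means a stronger inhibitor of growth, a higher number a weaker inhibitor of growth:

compound 1 `COc1ccc(C2=NN(C3=NC(=O)/C(=C4\C(=O)Nc5ccc(Br)cc54)S3)C(c3ccc(Cl)cc3)C2)cc1` — 340 nM
compound 2 `COc1ccc(C2=NN(C3=NC(=O)/C(=C4\C(=O)Nc5ccc(Cl)cc54)S3)C(c3ccc(Cl)cc3)C2)cc1` — 440 nM
compound 3 `CN(C)c1ccc(C2CC(c3ccccc3)=NN2C2=NC(=O)/C(=C3\C(=O)Nc4ccc(Br)cc43)S2)cc1` — 460 nM

Compound 1 and compound 2 share one core and differ in a single place: chloro in place of bromo on an aromatic carbon. That change produced a 1.3-fold higher number from compound 1 to compound 2 (0.11 log units; within the scatter), so the two values lie within the usual scatter of repeated measurements and no order between them can be read from the data. Compound 3 is built on another core; how the core of compound 3 differs from the core of compound 1 is not broken down here. In this assay compound 3 gives a value that also lies within the scatter of the values of compound 1 and compound 2, so none of the three can be called the stronger or weaker inhibitor of growth.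

Compound 4 `CN(C)c1ccc(C2CC(c3ccccc3)=NN2C2=NC(=O)/C(=C3\C(=O)Nc4ccc(Cl)cc43)S2)cc1` has not yet been measured. It differs from compound 3 in one place: chloro in place of bromo on an aromatic carbon. The place description is the same word for word as for the change from compound 1 to compound 2, so this is the same change applied on the core of compound 3.

For compound 4 a step of a 1.3-fold higher number from compound 3 to compound 4 (0.10 log units; within the scatter) is expected, because the same change earlier gave a 1.3-fold higher number from compound 1 to compound 2 (0.11 log units; within the scatter). Compound 4 is therefore estimated to give 580 nM in this assay. The estimate for compound 4 is expected to fall between 300 nM and 1150 nM.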

Compound 4, concentration for total growth inhibition: 570 nM
Beside the measured number, compound 4's estimate is 1.0-fold (0.01 log units) above it, within the range that was stated.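

In this assay, chloro in place of bromo on the second core gave a 1.2-fold higher number from compound 3 to compound 4 (0.09 log units; within the scatter), a step too small to set the two compounds apart. Set beside the earlier step, the swap looks the same on both cores, and the two steps cannot be told apart: the same change on two cores in this assay, a 1.3-fold higher number (0.11 log units; within the scatter) from compound 1 to compound 2 and a 1.2-fold higher number (0.09 log units; within the scatter) from compound 3 to compound 4, 1.0-fold (0.02 log units) apart, within the scatter of two such steps. This shows that, on these two cores, exchanging one halogen for the other leaves the number within the scatter each time, but it does not show that the exchange has any real effect on growth inhibition, and two pairs of compounds cannot show that the step would stay this small on a third core.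

The compounds shown carry only bromo or chloro at this place on the six-membered aromatic ring, so they leave open what a clearly different group there, such as a nitrile or a carboxylic acid, would do to the number, and whether such a group would act alike on both cores. Going by these compounds, only this one cell assay appears here as well, so it also stays open whether bromo and chloro would remain this close in any other test.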